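From chloro to methoxy: estimating compound 4

The source may report more compounds than this note shows. Statements on the series, on what has been measured and on what is new or still open speak of the compounds shown alone.

Compound 1 `CC1(C)[C@H]2CC[C@]1(C)N(Cc1cn(-c3ccccc3Br)nn1)C(=O)C2`: 140 nM
Compound 2 `CC1(C)[C@H]2CC[C@]1(C)N(Cc1cn(-c3ccccc3C#N)nn1)C(=O)C2`: 110 nM
Compound 3 `CC1(C)[C@H]2CC[C@]1(C)N(Cc1cn(-c3ccccc3Cl)nn1)C(=O)C2`: 40 nM
Compound 4 `COc1ccccc1-n1cc(CN2C(=O)C[C@@H]3CC[C@@]2(C)C3(C)C)nn1`: not yet measured

In a functional assay on OVCAR-3 cells (Homo sapiens) for inhibition, read by MTT assay, with a stated time of 24 h (on this read-out higher numbers stand for weaker inhibition and lower numbers for stronger inhibition), compound 3 gives the lowest of the three numbers, 40 nM, and its steps to both other compounds lie beyond the scatter. Compound 4 `COc1ccccc1-n1cc(CN2C(=O)C[C@@H]3CC[C@@]2(C)C3(C)C)nn1` differs from it in one place: methoxy in place of chloro on an aromatic carbon. Methoxy stands in place of chloro on an aromatic carbon, ortho to a large group.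

Within the data shown here, three measured steps concern this same place. Chloro in place of bromo gave a 3.5-fold lower number from compound 1 to compound 3 (0.54 log units; beyond the scatter), and chloro in place of cyano gave a 2.8-fold lower number from compound 2 to compound 3 (0.44 log units; beyond the scatter). Cyano in place of bromo gave a 1.3-fold lower number from compound 1 to compound 2 (0.10 log units; within the scatter), which is within the scatter. Both other groups tested there thus gave higher numbers than chloro, by modest amounts. Among the measured compounds shown here, no methoxy compound has been measured, and three compounds are a thin basis. A modest rise of similar size is therefore expected, namely a 2.5-fold higher number from compound 3 to compound 4 (0.40 log units; beyond the scatter). For compound 4 the estimated value is 100 nM, with an expected range of 35 nM to 280 nM.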

Compound 4, half-maximal inhibitory concentration: 140 nM
The estimate for compound 4 lay 1.4-fold (0.15 log units) below the measured number, and the stated range covers the measured number.
By their numbers in this assay, from the lowest: compound 3; then compounds 2, 1 and 4 (each within the scatter of the next).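

In this assay, methoxy in place of chloro gave a 3.5-fold higher number from compound 3 to compound 4 (0.54 log units; beyond the scatter), so a third group at this place, ortho to a large group, ends up with a higher number than chloro. Methoxy also does not separate from the other two groups, with a 1.3-fold higher number from compound 2 to compound 4 (0.10 log units; within the scatter) and no change at the digits printed from compound 1 to compound 4 (within the scatter), so chloro alone stands apart among the four groups shown, while bromo, cyano and methoxy lie within the scatter of one another. No measurement at hand bears on why chloro differs from these groups.

Going by these compounds, it remains open whether a methyl group, a fluoro group or an amine at this place would match chloro, or even give a lower number. On these data alone, it is also open whether the gap between chloro and methoxy would persist with either group elsewhere on the aromatic ring.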